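This account rests on a few compounds, and the source may have more. Where it says the series, first, only, none or still open, it means among the compounds named here.

Measured compounds in this series:

Compound 1 `CC(c1ccc(-c2ccccc2)c(F)c1)c1nnc2n1N=C(c1ccc(Cl)cc1)CS2`: 8700 nM
Compound 2 `CC(c1ccc(-c2ccccc2)c(F)c1)c1nnc2n1N=C(c1ccccc1)CS2`: 7400 nM
Compound 3 `Cc1ccc(C2=Nn3c(nnc3C(C)c3ccc(-c4ccccc4)c(F)c3)SC2)cc1`: 5000 nM

All three share one core and differ only in the aryl group on the carbon with a double bond to nitrogen. In a functional assay on MCF7 cells (Homo sapiens) for inhibition, read by sulforhodamine B assay, with a stated time of 72 h (a higher number here means a weaker inhibitor, a lower number a stronger inhibitor), compound 3 gives the lowest of the three numbers, but its separation from compound 2 and from compound 1 stays within the scatter, so no order among the three can be read from these data. The steps of a 1.2-fold lower number from compound 1 to compound 2 (0.07 log units; within the scatter), a 1.7-fold lower number from compound 1 to compound 3 (0.24 log units; within the scatter) and a 1.5-fold lower number from compound 2 to compound 3 (0.17 log units; within the scatter) are each within the scatter.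

Compound 4 `CC(c1ccc(-c2ccccc2)c(F)c1)c1nnc2n1N=C(c1ccc(Cl)cc1Cl)CS2` is not yet measured. Relative to compound 3 it carries 2,4-dichlorophenyl in place of 4-methylphenyl on a carbon with a double bond to nitrogen. The measured steps bearing on it are those that exchange chloro, hydrogen and methyl on the aromatic carbon; none moved the number beyond the scatter. Compound 1, which bears the single chloro, gives 8700 nM in this assay, and compound 4 keeps that chloro and adds a second. Going by the values given here, no measured step covers the added chloro, so the expectation rests on the chloro-bearing compound 1. Compound 4 is therefore expected to give 8000 nM (range 4000 nM to 17000 nM). The step from compound 3 implied by this estimate, a 1.6-fold higher number from compound 3 to compound 4 (0.20 log units; within the scatter), is expected to fall within or near the scatter.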

Compound 4, half-maximal inhibitory concentration: 7600 nM
Compound 4: middle estimate off by 1.1-fold (0.02 log units), on the high side; measured number inside the range.
By their numbers in this assay, from the lowest: compounds 3, 2, 4 and 1 (each within the scatter of the next).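

The aryl group on the carbon with a double bond to nitrogen now also includes 2,4-dichlorophenyl, and in this assay all three new comparisons stay within the scatter: the added chloro gives (a 1.1-fold lower number from compound 1 to compound 4 (0.06 log units; within the scatter)), the exchange for phenyl gives (a 1.0-fold higher number from compound 2 to compound 4 (0.01 log units; within the scatter)) and the exchange for 4-methylphenyl gives (a 1.5-fold higher number from compound 3 to compound 4 (0.18 log units; within the scatter)). Going by these compounds alone, the earlier compounds carried at most one substituent on this aryl group, so compound 4 is the first to show that a second one, here chloro, does not separate a compound from the others at this position. Across phenyl, the single chloro, the methyl and the two chloro groups, this position therefore gives no readable order, and no measured evidence bears on why the numbers lie so close together.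

As far as these compounds go, all four aryl groups carry only hydrogen, chloro or methyl, so the effect of an amine, a carboxylic acid or a methoxy group on this ring remains open. The rest of the structure is the same in all four compounds, so these data cannot show whether changes elsewhere would move the number beyond the scatter.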